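The compounds below may be only part of what the source reports. "The series", "measured", "known", "first", "only" and "open" are said of these compounds alone.

Of the compounds shown here, three built on one shared core have been measured in a functional assay on B16-F10 cells (Mus musculus) for antiproliferative activity, read by ELISA and MTT assay, with a stated time of 48 h; on this read-out lower numbers stand for stronger inhibition and higher numbers for weaker inhibition. Compound 1 `Cc1ccc(S(=O)(=O)NC(=O)/C=C/c2ccc(F)cc2)cc1` gives 4.8 ug/mL. Compound 2 `Cc1ccc(S(=O)(=O)NC(=O)/C=C/c2ccc(Br)cc2)cc1` gives 12.1 ug/mL, and compound 3 `COc1ccc(/C=C/C(=O)NS(=O)(=O)c2ccc(C)cc2)cc1` gives 12.2 ug/mL. Compound 3 lies furthest from compound 1, that step being a 2.5-fold higher number from compound 1 to compound 3 (0.41 log units; beyond the scatter), whereas the remaining step is a 1.0-fold higher number from compound 2 to compound 3 (0.00 log units; within the scatter). The next compound, compound 4 `Cc1ccc(S(=O)(=O)NC(=O)/C=C/c2ccc(N(C)C)cc2)cc1`, differs from compound 3 in one place only: dimethylamino in place of methoxy on an aromatic carbon. Among the compounds with values here, no measured step swaps these two groups. The nearest guides are a 2.5-fold higher number from compound 1 to compound 2 (0.40 log units; beyond the scatter) and a 2.5-fold higher number from compound 1 to compound 3 (0.41 log units; beyond the scatter), both modest, together with a 1.0-fold higher number from compound 2 to compound 3 (0.00 log units; within the scatter); they suggest only a small move, if any, in this assay. Compound 4 is therefore expected near 12 ug/mL, between 5 ug/mL and 28 ug/mL. The expected step is a 1.0-fold lower number from compound 3 to compound 4 (0.01 log units; within the scatter).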

Compound 4, half-maximal inhibitory concentration: 4.3 ug/mL
Beside the measured number, compound 4's estimate is 2.8-fold (0.45 log units) above it, and the stated range ends above it.
By their numbers in this assay, from the lowest: compounds 4 and 1 (each within the scatter of the next); then compounds 2 and 3 (each within the scatter of the next).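

Within the data shown here, at this position, dimethylamino gives the first step that improves on methoxy in this assay with a 2.8-fold lower number from compound 3 to compound 4 (0.45 log units; beyond the scatter) and improves on bromo by the same margin with a 2.8-fold lower number from compound 2 to compound 4 (0.45 log units; beyond the scatter) as well. Against fluoro it shows a 1.1-fold lower number from compound 1 to compound 4 (0.05 log units; within the scatter) and so no real difference, which means the lower level is not unique to fluoro. No measurement shown explains these steps. Still open, going by these compounds, is whether a primary amine or a carboxylic acid here would match dimethylamino and fluoro. Also open, on these data alone, is how diethylamino, with its longer chains, would compare.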